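A few compounds are considered here, and "the series" means these few. Any claim that something is new, unique, unknown or untested is made for them only; others in the source may bear on it.

In an ADME assay on the whole organism (Macaca fascicularis) for pharmacokinetics, read by LC-MS, using cassette dosing, at a dose of 1 mg/kg by the oral route (on this read-out lower numbers stand for lower exposure and higher numbers for higher exposure at the dose given), the two measured compounds gave these numbers:
Compound 1, `CCCCN(c1nc2c(NS(C)(=O)=O)cccc2o1)[C@H](C)c1ccc(-c2ccccc2-c2nnn[nH]2)cc1`, gives 73.8 ng.h/mL
Compound 2, `CCCCN(c1nc2c(-c3nccn3C)cccc2o1)[C@H](C)c1ccc(-c2ccccc2-c2nnn[nH]2)cc1`, gives 152 ng.h/mL

Compound 2 stands highest of the two numbers on this read-out. Among the measured compounds shown here, the only step measured so far, a 2.1-fold higher number from compound 1 to compound 2 (0.31 log units; beyond the scatter), is modest but lies beyond the scatter. Compound 3, `CCCCN(c1nc2c(-c3ccccn3)cccc2o1)[C@H](C)c1ccc(-c2ccccc2-c2nnn[nH]2)cc1`, has not been measured. It differs from compound 2 in one place: pyridin-2-yl in place of 1-methyl-1H-imidazol-2-yl on an aromatic carbon. The measured step concerns a different exchange, methanesulfonamido giving way to 1-methyl-1H-imidazol-2-yl at that same carbon, so it offers no direct guide to replacing one small aromatic ring by another there. With nothing in the data bearing on this particular swap, the expectation for compound 3 in this assay is a number near that of compound 2, with no step beyond the scatter, which is expressed as a 1.0-fold lower number from compound 2 to compound 3 (0.01 log units; within the scatter). The estimate for compound 3 is therefore 150 ng.h/mL, with a likely range from 60 ng.h/mL to 380 ng.h/mL.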

Compound 3, area under the concentration-time curve: 248 ng.h/mL
Estimate against measurement, compound 3: 1.7-fold (0.22 log units) below, and the stated range covers the measured number.
By their numbers in this assay, from the lowest: compound 1; then compounds 2 and 3 (each within the scatter of the next).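

In this assay, putting pyridin-2-yl, a six-membered aromatic ring with 1 hetero atom, in place of 1-methyl-1H-imidazol-2-yl, a five-membered aromatic ring with 2 hetero atoms, gives a 1.6-fold higher number from compound 2 to compound 3 (0.21 log units; within the scatter), so this read-out does not separate these two rings at this aromatic carbon. Measured against methanesulfonamido, pyridin-2-yl gives a 3.4-fold higher number from compound 1 to compound 3 (0.53 log units; beyond the scatter), a modest step, and the earlier 2.1-fold higher number from compound 1 to compound 2 (0.31 log units; beyond the scatter) now has a second example: among these three compounds, both aromatic rings stand beyond the scatter from the methanesulfonamido compound, so the earlier step is not tied to the imidazole ring alone. No measurement shown here bears on what lies behind these numbers.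

The compounds shown leave open whether a plain phenyl ring, with no hetero atom, or a non-aromatic amine such as morpholin-4-yl at this carbon would fall with the two aromatic rings or with methanesulfonamido. They also leave open whether the same picture holds once the butyl chain or another part of the shared core is changed, since all three compounds keep these parts unchanged.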